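A Ketone Enters the Side Chain of Compound 3

A few compounds are considered here, and "the series" means these few. Any claim that something is new, unique, unknown or untested is made for them only; others in the source may bear on it.

Compound 1 `COc1cc(/C=C/C(=O)/C=C(O)/C=C/c2ccc(O[C@H]3C=C(C)[C@@H](O)C[C@@H]3[C@@H](C)CCC=C(C)C)c(OC)c2)ccc1O`: 27300 nM
Compound 2 `COc1cc(/C=C/C(=O)/C=C(O)/C=C/c2ccc(O[C@H]3C[C@H]([C@@H](C)CCC=C(C)C)[C@@H](O)C=C3C)c(OC)c2)ccc1O`: 74900 nM
Compound 3 `COc1cc(/C=C/C(=O)/C=C(O)/C=C/c2ccc(O[C@H]3C[C@H]([C@@H](C)CCC=C(C)C)C=C[C@@]3(C)O)c(OC)c2)ccc1O`: 24600 nM

Three compounds sharing the same core were measured in a functional assay on MDA-MB-231 cells (Homo sapiens) for cytotoxicity, read by crystal violet staining, with a stated time of 72 h; a lower number here means a stronger inhibitor, a higher number a weaker inhibitor. Compound 3 gives the lowest number of the three, but its gap to compound 1 is within the scatter of the measurement, so the two cannot be ordered. Within the data shown here, compound 2 stands beyond the scatter above compound 3, and since these three differ from one another in more than one place, no single structural step is drawn between them.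

The next compound, compound 4 `COc1cc(/C=C/C(=O)/C=C(O)/C=C/c2ccc(O[C@H]3C[C@H]([C@@H](C)CC(=O)C=C(C)C)C=C[C@@]3(C)O)c(OC)c2)ccc1O`, differs from compound 3 in one place: (2-methylprop-1-en-1-yl)carbonyl in place of 3-methylbut-2-en-1-yl on a saturated chain carbon, two bonds along the chain from a saturated ring carbon. Among the measured compounds shown here, a carbonyl is added to the chain and an acceptor is counted where none was before, but nothing among the measured compounds shows what such a change does in this assay.

Compound 4 is therefore expected to sit close to compound 3, with a step of a 1.1-fold lower number from compound 3 to compound 4 (0.05 log units; within the scatter) that does not go beyond the scatter in either direction. The estimate for compound 4 in this assay is 22000 nM, with a range from 8000 nM to 60000 nM, pending the measurement.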

Compound 4, half-maximal inhibitory concentration: 15900 nM
Beside the measured number, compound 4's estimate is 1.4-fold (0.14 log units) above it; low and high end bracket the measured number.
By their numbers in this assay, from the lowest: compounds 4, 3 and 1 (each within the scatter of the next); then compound 2.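

In this assay, among these compounds, the first step in this set that changes a single place, (2-methylprop-1-en-1-yl)carbonyl in place of 3-methylbut-2-en-1-yl on a saturated chain carbon, two bonds along the chain from a saturated ring carbon, gives a 1.5-fold lower number from compound 3 to compound 4 (0.19 log units; within the scatter). The earlier compounds shown here differed from one another in more than one place and could say nothing about this side chain, whereas this pair shows that a carbonyl, with its one hydrogen-bond acceptor and one more heavy atom, can enter the chain without moving the number beyond the scatter. No measurement at hand bears on what lies behind this result.

The compounds shown leave open whether a larger step would follow if the chain at this place carried a hydroxyl group, an amine or a carboxylic acid instead of the carbonyl. They also leave open whether the same replacement would give a comparable step on the core of compound 1 or compound 2, which stand apart from compound 3 in other places.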